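Sulfonyl hydrazone series: dimethylamino replaced by isopropyl

This account rests on a few compounds, and the source may have more. Where it says the series, first, only, none or still open, it means among the compounds named here.

Working notes on the series built around the shared core carrying the nitrile. Among the measured compounds shown here, compound 1 `CN(C)c1ccc([N+](=O)[O-])cc1S(=O)(=O)N(C)/N=C/c1cnn2ccc(C#N)cc12` is the only member with a number so far: in a functional assay on NZB5 cells (Homo sapiens) for inhibition, read by thymidine incorporation, with a stated time of 5 days (a lower number here means a stronger inhibitor, a higher number a weaker inhibitor), compound 1 gives 40 nM. Compound 2 `Cc1ccc([N+](=O)[O-])cc1S(=O)(=O)N(Cc1ccccc1)/N=C/c1cnn2ccc(C#N)cc12` belongs to the same series, but in this assay compound 2 gives "not determined" (no result reported), so nothing can be said of how the two compare, and compound 2 differs from compound 1 in more than one place anyway. For the measured compounds named here, no step between two measured compounds exists in this set.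

Compound 3 `CC(C)c1ccc([N+](=O)[O-])cc1S(=O)(=O)N(C)/N=C/c1cnn2ccc(C#N)cc12` is the next compound to be measured. It differs from compound 1 in one place: isopropyl in place of dimethylamino on an aromatic carbon. With no step of this kind among the measured compounds, the size and direction of the effect in this assay cannot be read off anything shown; a moderate step is expected, somewhat more likely toward weaker inhibition than toward stronger, and it may yet fall within the scatter. The estimated step from compound 1 to compound 3 is a 2.0-fold higher number from compound 1 to compound 3 (0.30 log units; within the scatter). For compound 3 the expected value in this assay is 80 nM, with a range from 25 nM to 250 nM.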

Compound 3, half-maximal inhibitory concentration: 180 nM
Compound 3: middle estimate off by 2.3-fold (0.35 log units), on the low side; low and high end bracket the measured number.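

In this assay, among the compounds shown here, isopropyl in place of dimethylamino, on the aromatic carbon ortho to a large group and para to a nitro group, gives a 4.5-fold higher number from compound 1 to compound 3 (0.65 log units; beyond the scatter), the first step that can be read, and it lies beyond the scatter towards weaker inhibition. This position is therefore not indifferent to the group it carries, even in an exchange that keeps 3 heavy atoms, no ring and no net charge on both sides: dimethylamino holds a nitrogen and 1 hydrogen-bond acceptor, while isopropyl holds carbon only and no acceptor. Nothing measured in the compounds shown accounts for the size or direction of this step.

As far as these compounds go, a single pair cannot separate the part played by the nitrogen from that of the rest of the group, so what the position tolerates beyond these two groups stays open. A primary amine, a methoxy group or a cyclopropyl group on the same carbon would bear on that question, as would a longer chain such as diethylamino.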